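Swapping a Phenyl for Chloro on an Agonist Tail

This account rests on a few compounds, and the source may have more. Where it says the series, first, only, none or still open, it means among the compounds named here.

Of the compounds shown here, three have been measured in a functional assay on CHO cells for agonist activity at prostaglandin E2 receptor EP4 subtype (Rattus norvegicus), read by cAMP accumulation and immunoassay, with a stated time of 10 min; on this read-out lower numbers stand for an effect already at smaller amounts and higher numbers for an effect only at larger amounts of compound. Compound 1 `O=C(O)CCCSCCN1C(=O)SC[C@@H]1/C=C/[C@@H](O)Cc1ccccc1` gives 4.8 nM. Compound 3 `COCc1cccc(C[C@H](O)/C=C/[C@H]2[C@H](O)CC(=O)[C@@H]2CCSCCCC(=O)O)c1`, built on a different core, gives 1.4 nM. Compound 2 `O=C(O)CCCSCCN1C(=O)OC[C@@H]1/C=C/[C@@H](O)Cc1cccc(-c2ccccc2)c1` gives 450 nM, the highest of the three numbers: its gap to compound 1 and its gap to compound 3 both lie well beyond the scatter of repeated measurements, so compound 2 is the least potent of the measured set.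

Compound 4 `O=C(O)CCCSCCN1C(=O)OC[C@@H]1/C=C/[C@@H](O)Cc1cccc(Cl)c1` differs from compound 2 in one place: chloro in place of phenyl on an aromatic carbon. Going by the values given here, no measured pair shows exactly this change, so the expectation rests on what the three numbers show. Compound 1, with an unsubstituted phenyl ring, gives 4.8 nM, and compound 3, carrying a methoxymethyl group on its ring, gives 1.4 nM; only compound 2, with its phenyl, sits far higher. A small chloro group is therefore expected to move compound 4 back towards the lower numbers, giving a large step downwards in this assay of about a 23-fold lower number from compound 2 to compound 4 (1.35 log units; beyond the scatter). For compound 4 a value near 20 nM is estimated, within a range from 5 nM to 100 nM.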

Compound 4, half-maximal effective concentration: 23 nM
Compound 4: middle estimate off by 1.2-fold (0.06 log units), on the low side, within the range that was stated.
By their numbers in this assay, from the lowest: compound 3; then compound 1; then compound 4; then compound 2.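

In this assay, going by these compounds alone, the swap gives the first reading of a change in one place alone, a 20-fold lower number from compound 2 to compound 4 (1.29 log units; beyond the scatter), so the group on this aromatic carbon, meta to a large group, clearly bears on the number: with the rest of the molecule held the same, the phenyl goes with the higher number and the chloro with the lower one. The two groups differ in size and shape, with phenyl bringing 6 heavy atoms and a six-membered aromatic ring and chloro bringing 1 heavy atom and no ring, but they match in having no hydrogen-bond donors, no hydrogen-bond acceptors and no net charge, so the step cannot be tied to a change in those counts. No measurement shown here explains why the number moves.

A single step cannot tell whether the loss of the ring, the drop in atom count or the chlorine itself goes with the lower number. Groups such as fluoro, methyl, methoxy or an amine on the same carbon would help separate these, and a plain hydrogen there would show whether the chloro is better than no group at all.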